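A few compounds are considered here, and "the series" means these few. Any claim that something is new, unique, unknown or untested is made for them only; others in the source may bear on it.

Measured so far in a functional assay on A549 cells (Homo sapiens) for antiproliferative activity, read by MTT assay; a higher number here means a weaker inhibitor, a lower number a stronger inhibitor:
- compound 1 `CC1(C)CCc2c(ccc(C(=O)/C=C/c3ccc(OCc4cn(-c5ccc(Br)cc5)nn4)cc3)c2O)O1` gives 129000 nM
- compound 2 `COc1ccc(-n2cc(COc3ccc(/C=C/C(=O)c4ccc5c(c4O)CCC(C)(C)O5)cc3)nn2)c([N+](=O)[O-])c1` gives "not active" (no number reported)
- compound 3 `Cc1ccc(-n2cc(COc3ccc(/C=C/C(=O)c4ccc5c(c4O)CCC(C)(C)O5)cc3)nn2)cc1Br` gives "not active" (no number reported)

Compound 3 has no single number in this assay and, like compound 2, sits without a value. Compound 4 `CCCCCCCCn1cc(COc2ccc(/C=C/C(=O)c3ccc4c(c3O)CCC(C)(C)O4)cc2)nn1` carries octyl in place of 3-bromo-4-methylphenyl on an aromatic nitrogen. Within the data shown here, no measured compound has an open chain at this place, so the step is poorly anchored. A modest step towards stronger inhibition is expected, enough to give a number, although a further result without a number remains quite possible. Among the measured compounds shown here, the expectation stays near the only number available, compound 1 at 129000 nM. For compound 4 the estimated value is 60000 nM, with an expected range of 15000 nM to 200000 nM.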

Compound 4, half-maximal inhibitory concentration: "not active" (no number reported)
Compound 4: no number reported, so the estimate cannot be set against anything.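

Compound 3 and compound 4 both lack a number in this assay so no step can be read between them. No supporting evidence bears on this result.

The compounds shown leave open how the group on the aromatic nitrogen relates to activity in the series, since compound 1 alone carries a number.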